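Swapping 4-bromophenyl for 2-methylphenyl on compound 2

The source may report more compounds than this note shows. Statements on the series, on what has been measured and on what is new or still open speak of the compounds shown alone.

- compound 1 `CCCCCCC(C)Nc1nc2cc(-c3ccc(C)cc3)sc2c(=O)[nH]1` gives 19400 nM
- compound 2 `CC(C)(C)Nc1nc2cc(-c3ccc(Br)cc3)sc2c(=O)[nH]1` gives 1400 nM
- compound 3 `CC(C)Nc1nc2cc(-c3ccc(Br)cc3)sc2c(=O)[nH]1` gives 13400 nM

All three numbers come from an ADME assay on HepG2 cells (Homo sapiens) for cytotoxicity, read by MTT assay, with a stated time of 72 h (a lower number here means that less compound is tolerated, a higher number that more compound is tolerated), and compound 2 stands lowest of them. Compound 3 lies closest to it, and compound 1 lies furthest away.

Compound 4 `Cc1ccccc1-c1cc2nc(NC(C)(C)C)[nH]c(=O)c2s1` has not yet been measured. It differs from compound 2 in one place, on an aromatic carbon next to the ring sulfur. The change is 2-methylphenyl in place of 4-bromophenyl on an aromatic carbon and the rest of the molecule stays the same.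

Going by the values given here, no measured pair isolates this change. Among the compounds with values here, the only measured step concerns the chain on the nitrogen instead, and it is a 9.6-fold higher number from compound 2 to compound 3 (0.98 log units; beyond the scatter) which shows that one small edit in this set can move the number well beyond the scatter. Compound 1 differs from compound 2 in more than one place, so it cannot isolate the change either.

With compound 2 at 1400 nM as the lowest of the three, a modest rise in this assay is expected, although a step within the scatter remains possible. Compound 4 is therefore estimated at 3500 nM with an expected range from 900 nM to 15000 nM as its upper end. That estimate means a 2.5-fold higher number from compound 2 to compound 4 (0.40 log units; beyond the scatter) as the expected step.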

Compound 4, half-maximal cytotoxic concentration: 4000 nM
Compound 4: the middle estimate sits 1.1-fold (0.06 log units) below what was measured, within the range that was stated.
By their numbers in this assay, from the lowest: compound 2; then compound 4; then compounds 3 and 1 (each within the scatter of the next).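

In this assay, the group on an aromatic carbon next to the ring sulfur now has a measured step of its own: 2-methylphenyl in place of 4-bromophenyl gives a 2.9-fold higher number from compound 2 to compound 4 (0.46 log units; beyond the scatter) with the rest of the molecule unchanged. Going by these compounds alone, until now, the only single-place step concerned the chain on the nitrogen, at a 9.6-fold higher number from compound 2 to compound 3 (0.98 log units; beyond the scatter) and also beyond the scatter, so edits at both places can move this number more than repeated measurements would. The two groups on the ring match in heavy-atom count and in hydrogen-bond donors and acceptors, and nothing available here explains why swapping them shifts the tolerated concentration.

This single swap changes both the substituent and its place on the phenyl ring, so the separate contributions of bromine, methyl and their placement remain unresolved, and a compound carrying 2-bromophenyl with the chain of compound 2 would help to separate them. Also open, from the compounds shown here alone, is whether the same swap would give a similar step with the chain of compound 3, and how an unsubstituted phenyl or a pyridine ring would behave at this position.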